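The source may hold more compounds than are shown below. What is called first, only, known or untested is meant among the compounds shown, and "the series" means these compounds.

Compound 1 `COc1ccc(C=C2C(=O)N(c3ccc(Cl)cc3)N(c3ccc(Cl)cc3)C2=O)cc1OC`: > 128000 nM
Compound 2 `COc1cccc(C=C2C(=O)N(c3ccc(Cl)cc3)N(c3ccc(Cl)cc3)C2=O)c1OC`: 11900 nM

Going by the values given here, in a functional assay on MCF7 cells (Homo sapiens) for cytotoxicity, read by MTT assay, with a stated time of 72 h (a higher number here means a weaker inhibitor, a lower number a stronger inhibitor), compound 2 gives 11900 nM, the only exact number so far. Compound 1 gives > 128000 nM, which is a limit. Compound 3 `O=C1C(=Cc2ccc(Cl)cc2Cl)C(=O)N(c2ccc(Cl)cc2)N1c1ccc(Cl)cc1` carries 2,4-dichlorophenyl in place of 2,3-dimethoxyphenyl on a double-bonded chain carbon bound to a double-bonded ring carbon. Among the compounds with values here, the one measured step at this place, an at least 10-fold lower number from compound 1 to compound 2 (1.03 log units; beyond the scatter), was large, so a change here can matter. That step only rearranged the methoxy groups, and no 2,4-dichlorophenyl compound has been measured, so no direction is favoured and no step beyond the scatter is expected. The expected step is a 1.3-fold higher number from compound 2 to compound 3 (0.10 log units; within the scatter). For compound 3 the estimate is 15000 nM, with an expected range from 3000 nM to 80000 nM.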

Compound 3, half-maximal inhibitory concentration: > 128000 nM
Compound 3 gave a limit, no number (the forecaster's own chance of this, stated with the estimate: 15%); at least 8.5-fold (0.93 log units) between middle value and limit.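

Replacing 2,3-dimethoxyphenyl with 2,4-dichlorophenyl gives an at least 10-fold higher number from compound 2 to compound 3 (1.03 log units; beyond the scatter), so at this place the result in this assay can shift with a change of substituent as well as with a rearrangement of the methoxy groups. The value of compound 3 is a limit, not a number, so the step from compound 1 to compound 3 cannot be read. Of the three groups shown, only 2,3-dimethoxyphenyl gives an exact number, while the other two share one limit: the limit of > 128000 nM in this assay, at which 2 of the 3 values shown sit.

From the compounds shown here alone, it remains open how a phenyl ring carrying a single methoxy group or an amine would behave at this place. Going by these compounds, it also remains open whether either chlorine of 2,4-dichlorophenyl alone would give a readable number.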